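Phenyl replaces (trifluoromethyl)carbonyl on an amine nitrogen

A few compounds are considered here, and "the series" means these few. Any claim that something is new, unique, unknown or untested is made for them only; others in the source may bear on it.

In an ADME assay on microsomes (Rattus norvegicus) for metabolic stability (on this read-out higher numbers stand for a longer-lived compound and lower numbers for a shorter-lived compound), three compounds have been measured so far. Compound 1 (`Cc1ccc(C2CC=NN2C(=O)C(C)(C)C)cc1`) gives 0.0383 h, compound 2 (`CCC(=O)N1CCC(C(=O)N2N=CCC2c2ccccc2)CC1`) gives 1.07 h, and compound 3 (`O=C(C1CCN(C(=O)C(F)(F)F)CC1)N1N=CCC1c1ccccc1`) gives 0.483 h. Compound 3 therefore stands second highest of the three, below compound 2 and above compound 1.

Compound 4 (`O=C(C1CCN(c2ccccc2)CC1)N1N=CCC1c1ccccc1`) has phenyl in place of (trifluoromethyl)carbonyl on an amine nitrogen in a ring. For the measured compounds named here, only one measured step bears on this change: a 2.2-fold lower number from compound 2 to compound 3 (0.35 log units; beyond the scatter). This modest step, beyond the scatter, swapped ethyl for trifluoromethyl on a carbonyl carbon. Going by the values given here, it keeps the carbonyl that compound 4 loses, so it offers only a loose guide, and no measured compound carries phenyl at this place. A modest move to a lower number is nevertheless expected, with wide uncertainty in this assay. The expected change is a 2.4-fold lower number from compound 3 to compound 4 (0.38 log units; beyond the scatter). The estimate for compound 4 is 0.2 h, with an expected range from 0.06 h to 0.7 h.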

Compound 4, half-life: 0.25 h
The estimate for compound 4 lay 1.3-fold (0.10 log units) below the measured number; low and high end bracket the measured number.
By their numbers in this assay, from the lowest: compound 1; then compounds 4 and 3 (each within the scatter of the next); then compound 2.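

In this assay, phenyl on the amine nitrogen in a ring gives a 1.9-fold lower number from compound 3 to compound 4 (0.29 log units; within the scatter) against (trifluoromethyl)carbonyl, so these two groups cannot be told apart on this read-out, although only the latter holds a carbonyl. Against propanoyl, the same place gives a 4.3-fold lower number from compound 2 to compound 4 (0.63 log units; beyond the scatter) and this step lies beyond the scatter, so the three compounds now show compound 2 clear of both compound 3 and compound 4, and a carbonyl at this place does not by itself set the number. No measurement shown here accounts for these numbers.

On these data alone, it remains open whether a phenyl ring carrying fluorine or a methoxy group, or a pyridine ring in its place, would stand with compound 4 or move away from it. As far as these compounds go, whether a methanesulfonyl group or a plain methyl group on this nitrogen would reach the level of compound 2 is equally open.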